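Removing the Methylsulfanyl Group from Compound 3

A few compounds are considered here, and "the series" means these few. Any claim that something is new, unique, unknown or untested is made for them only; others in the source may bear on it.

Compound 1 `CSc1ccc(CNc2nc([SeH])nc3ccccc23)cc1`, compound 2 `CCCCC[Se]c1nc(NCc2ccc(SC)cc2)c2ccccc2n1` and compound 3 `CSc1ccc(CNc2nc([Se]C)nc3ccccc23)cc1` share one core and differ only in the group bound to selenium. In a functional assay on HT-29 cells (Homo sapiens) for cytotoxicity, read by MTT assay, with a stated time of 72 h (on this read-out lower numbers stand for stronger inhibition of growth and higher numbers for weaker inhibition of growth), compound 1 gives 42900 nM, compound 2 gives 83600 nM and compound 3 gives 72700 nM. The steps of a 1.9-fold higher number from compound 1 to compound 2 (0.29 log units; within the scatter), a 1.7-fold higher number from compound 1 to compound 3 (0.23 log units; within the scatter) and a 1.1-fold lower number from compound 2 to compound 3 (0.06 log units; within the scatter) all lie within the scatter, so compound 3 stands second highest of the three numbers and close to both of the others. Compound 4 `C[Se]c1nc(NCc2ccccc2)c2ccccc2n1` differs from compound 3 by hydrogen in place of methylsulfanyl on an aromatic carbon. Among the measured compounds shown here, none of the measured steps touches this aromatic position, since each of them alters only the group on selenium, and each was small. Compound 4 is therefore expected to give about 70000 nM in this assay, between 25000 nM and 200000 nM, the estimated step of a 1.0-fold lower number from compound 3 to compound 4 (0.02 log units; within the scatter) being expected to stay within the scatter.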

Compound 4, concentration for 50% growth inhibition: 42800 nM
The estimate for compound 4 lay 1.6-fold (0.21 log units) above the measured number; low and high end bracket the measured number.
By their numbers in this assay, from the lowest: compounds 4, 1, 3 and 2 (each within the scatter of the next).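

Among the compounds shown here, the change on an aromatic carbon, para to a large group, is the first here that lies away from selenium, and in this assay hydrogen in place of methylsulfanyl gives a 1.7-fold lower number from compound 3 to compound 4 (0.23 log units; within the scatter) and so stays within the scatter. This position can therefore lose methylsulfanyl without a change beyond the scatter, as the group on selenium could be altered. No measurement at hand accounts for this result.

From the compounds shown here alone, whether an amine, a carboxylic acid or a methoxy group at this position would also stay within the scatter remains open. Also open, going by these compounds, is whether hydrogen here would give the same picture with pentyl on selenium.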